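Removing Chlorine from Compound 1 in Microsomal Clearance

A few compounds are considered here, and "the series" means these few. Any claim that something is new, unique, unknown or untested is made for them only; others in the source may bear on it.

Compound 1 `O=S(=O)(c1ccc(F)cc1)c1cnc2cc(F)c(Cl)cc2c1-c1ccc(Cl)cc1` gives 0.01 mL/min in an ADME assay on microsomes from liver (Homo sapiens) for metabolic stability, tested at 2.5 uM; on this read-out lower numbers stand for slow clearance and higher numbers for fast clearance. Compound 3 `O=S(=O)(c1ccc(F)cc1)c1cnc2ccc(Cl)cc2c1-c1ccc(Cl)cc1` gives 0.01 mL/min, level with compound 1 within the scatter; together they are the lowest of the three numbers. Compound 2 `COc1cccc(-c2c(S(=O)(=O)c3cc(F)cc(F)c3)cnc3c(F)cccc23)c1` sits far higher, at 2.76 mL/min. The step of no change at the digits printed from compound 1 to compound 3 (within the scatter) shows that hydrogen in place of fluoro on an aromatic carbon left the read-out unchanged. Compound 4 `O=S(=O)(c1ccc(F)cc1)c1cnc2cc(F)ccc2c1-c1ccc(Cl)cc1` differs from compound 1 by hydrogen in place of chloro on an aromatic carbon. Going by the values given here, the only measured step bearing on this is the one from compound 1 to compound 3, which lies within the scatter, so no change beyond the scatter is expected for compound 4 in this assay. Compound 4 is estimated at 0.012 mL/min, with a range from 0.005 mL/min to 0.035 mL/min. This expectation corresponds to a step of a 1.2-fold higher number from compound 1 to compound 4 (0.08 log units; within the scatter).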

Compound 4, intrinsic clearance in a liver preparation (reported as CLH), per the amount of preparation that the assay uses: 1.23 mL/min
Estimate against measurement, compound 4: 100-fold (2.01 log units) below; the whole stated range lies below it.
By their numbers in this assay, from the lowest: compounds 1 and 3 (each within the scatter of the next); then compound 4; then compound 2.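

In this assay, hydrogen in place of chloro on this aromatic carbon, ortho to a fluoro group, gives a 120-fold higher number from compound 1 to compound 4 (2.09 log units; beyond the scatter), while hydrogen in place of fluoro gives no change at the digits printed from compound 1 to compound 3 (within the scatter). The two halogens on this ring are therefore not interchangeable in this series, and the low number of compound 1 depends on the chloro group at this position. No measured evidence on the origin of this large step is available here.

As far as these compounds go, it remains open whether a methyl, a methoxy or an amine at this carbon would keep the number low. From the compounds shown here alone, the size of the step without the neighbouring fluoro group is also open.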